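Swapping One Substituted Phenyl for Another in Cytotoxicity

A few compounds are considered here, and "the series" means these few. Any claim that something is new, unique, unknown or untested is made for them only; others in the source may bear on it.

Compound 3 `COC(=O)c1ccc(NCc2cncn2Cc2ccccc2Br)cc1-c1ccccc1` holds the lowest of the two readable numbers in a toxicity assay on NIH3T3 cells (Mus musculus) for cytotoxicity, read by resazurin assay (a higher number here means that more compound is needed for the effect, a lower number that less compound is needed), giving 10000 nM. Its nearest neighbour is compound 2 `COC(=O)c1ccc(NCc2cncn2Cc2ccccc2N)cc1-c1ccccc1`, which gives 25000 nM; the step of a 2.5-fold lower number from compound 2 to compound 3 (0.40 log units; beyond the scatter) is modest but beyond the scatter. Compound 1 `COC(=O)c1ccc(NCc2cncn2Cc2cccc([N+](=O)[O-])c2)cc1-c1ccccc1` reaches only the limit of this assay, > 10000 nM. Compound 4 `COC(=O)c1ccc(NCc2cncn2Cc2cccc(Cl)c2)cc1-c1ccccc1` differs from compound 3 by 3-chlorophenyl in place of 2-bromophenyl on a saturated chain carbon bound to an aromatic nitrogen. Among the compounds with values here, no measured step exchanges one substituted phenyl for another of the same kind: a number no higher from compound 1 to compound 3 (the limit leaves the size open) cannot be read because of the limit (the limit of > 10000 nM in this assay, at which 1 of the 3 values shown sits), and the bromo in place of amino step is the only readable one. With the values lying close together, compound 4 is expected to show a 1.2-fold higher number from compound 3 to compound 4 (0.08 log units; within the scatter) in this assay, within the scatter. Compound 4 is therefore estimated at 12000 nM, between 5000 nM and 30000 nM.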

Compound 4, half-maximal effective concentration: > 10000 nM
Compound 4: a limit, no number; the forecaster's own chance of this, stated with the estimate: 40%; the middle value is on the limit's open side.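

In this assay compound 4 gives > 10000 nM, which is a limit and not a number. Exchanging 2-bromophenyl for 3-chlorophenyl gives a number no lower from compound 3 to compound 4 (the limit leaves the size open), so this change brings no drop in the number. The steps linking compound 4 to compound 1 and compound 2 cannot be read because of the limit: the limit of > 10000 nM in this assay, at which 2 of the 4 values shown sit.

On these data alone, since this change alters both the halogen and its place on the phenyl ring, the effect of each alone remains open. Also open, as far as these compounds go, is how a phenyl carrying a carboxylic acid would read here.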